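The source may hold more compounds than are shown below. What is called first, only, known or untested is meant among the compounds shown, and "the series" means these compounds.

Among the compounds with values here, in a functional assay on HCT-116 cells (Homo sapiens) for antiproliferative activity, read by MTT assay, with a stated time of 48 h (a lower number here means a stronger inhibitor, a higher number a weaker inhibitor), compound 1 (`COc1ccc(-c2cc3c(cn2)[nH]c(=O)n3-c2cc(OC)c(OC)c(OC)c2)cc1O`) gives 340 nM, the lower of the two numbers measured so far. Within the data shown here, the only other measured compound, compound 2 (`COc1ccc(-c2cc3c(cn2)[nH]c(=O)n3-c2cc(OC)c(OC)c(OC)c2)cc1C`), gives 1810 nM. These two differ by methyl in place of hydroxy on an aromatic carbon, and a 5.3-fold higher number from compound 1 to compound 2 (0.73 log units; beyond the scatter) is a modest step. Compound 3 (`COc1ccc(-c2cc3c(cn2)n(C(C)C)c(=O)n3-c2cc(OC)c(OC)c(OC)c2)cc1O`) keeps the hydroxy group of compound 1 and changes a different place: isopropyl in place of hydrogen on an aromatic nitrogen, (isopropyl in place of hydrogen on an aromatic nitrogen). Among the measured compounds shown here, no measured step touches that nitrogen. The one step available was made at another place, so it offers no direction for this change, only a rough sense of how far a single change can move the number among these compounds. With so little evidence, no shift beyond the scatter is expected in either direction, although a move of similar size to that modest step remains possible. The expected step is a 1.1-fold lower number from compound 1 to compound 3 (0.05 log units; within the scatter). For compound 3, the estimated value in this assay is 300 nM, with an expected range from 70 nM to 1500 nM.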

Compound 3, half-maximal inhibitory concentration: 6660 nM
Beside the measured number, compound 3's estimate is 22-fold (1.35 log units) below it, outside the stated range (above it).
By their numbers in this assay, from the lowest: compound 1; then compound 2; then compound 3.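

Within the data shown here, this is the first measured change at the aromatic nitrogen of the five-membered ring, and in this assay placing isopropyl there in place of hydrogen gives a 20-fold higher number from compound 1 to compound 3 (1.29 log units; beyond the scatter) and so clearly weakens the compound. The position is therefore far from indifferent to substitution, and this large step stands against the modest 5.3-fold higher number from compound 1 to compound 2 (0.73 log units; beyond the scatter) seen at the other place changed in this small set. Nothing measured here accounts for the loss of activity.

The compounds shown leave open whether any group on this nitrogen brings a similar loss or whether it is tied to isopropyl itself; a methyl group, an ethyl group or a longer chain ending in an amine or a carboxylic acid could help separate these possibilities. From the compounds shown here alone, it is also open whether the isopropyl step would have the same size with methyl rather than hydroxy on the aromatic carbon, as in compound 2, since the two changes are seen here only one at a time.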